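This account rests on a few compounds, and the source may have more. Where it says the series, first, only, none or still open, it means among the compounds named here.

Compound 1 `O=S(=O)(/C=C/c1ncccc1Cl)c1cccc(F)c1`: 84 nM
Compound 2 `O=S(=O)(/C=C/c1ccccn1)c1cccc(Cl)c1`: 1430 nM
Compound 3 `O=S(=O)(/C=C/c1ncccc1F)c1cccc(Cl)c1`: 198 nM

All three numbers come from an assay on U2OS cells for activation of nuclear factor erythroid 2-related factor 2 (Homo sapiens), read by beta-arrestin recruitment, with a stated time of 6 h; on this read-out lower numbers stand for an effect already at smaller amounts and higher numbers for an effect only at larger amounts of compound. Compound 3 stands second highest of the three: compound 1 gives 84 nM, a lower number beyond the scatter, while compound 2 gives 1430 nM, a higher number beyond the scatter.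

Compound 4 `O=S(=O)(/C=C/c1ncccc1Cl)c1cccc(Cl)c1` differs from compound 3 in one place: chloro in place of fluoro on an aromatic carbon. Among the measured compounds shown here, only one measured step touches this position, a 7.2-fold lower number from compound 2 to compound 3 (0.86 log units; beyond the scatter), which shows that a halogen at this carbon matters. For the measured compounds named here, no measured pair swaps chloro for fluoro, so the expectation rests on that single step alone. The step of a 1.8-fold lower number from compound 3 to compound 4 (0.26 log units; within the scatter) is therefore expected to be small, toward a slightly lower number. Compound 4 is estimated at 110 nM, within a range from 50 nM to 260 nM.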

Compound 4, half-maximal effective concentration: 46 nM
Beside the measured number, compound 4's estimate is 2.4-fold (0.38 log units) above it; measured number outside the range, below it.
By their numbers in this assay, from the lowest: compounds 4 and 1 (each within the scatter of the next); then compound 3; then compound 2.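

At this carbon the kind of halogen counts, not only its presence: fluoro to chloro gives a 4.3-fold lower number from compound 3 to compound 4 (0.63 log units; beyond the scatter) here, and hydrogen to chloro gives a 31-fold lower number from compound 2 to compound 4 (1.49 log units; beyond the scatter) overall. The same swap on the other ring gives a 1.8-fold lower number from compound 1 to compound 4 (0.26 log units; within the scatter) and so shows no clear change, which means this swap does not count equally at both places. As far as these compounds go, whether bromo, methyl or an amine at the first carbon would lower the number further remains open. Nothing shown gives a reason for these differences.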